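This account rests on a few compounds, and the source may have more. Where it says the series, first, only, none or still open, it means among the compounds named here.

Compound 1 `CS(=O)(=O)c1ccc2nc(NC(=O)CCCCCCC(=O)NO)sc2c1`: 13.5 ug/mL
Compound 2 `Cc1ccc2nc(NC(=O)CCCCCCC(=O)NO)sc2c1`: 0.54 ug/mL
Compound 3 `Cc1ccc2nc(NC(=O)CCCCC(=O)NO)sc2c1`: 13.3 ug/mL

All values are from a functional assay on ASPC1 cells (Homo sapiens) for cytotoxicity; on this read-out higher numbers stand for weaker inhibition and lower numbers for stronger inhibition. Compound 3 lies within the scatter of compound 1, and both sit well above compound 2; the chain step is a 25-fold higher number from compound 2 to compound 3 (1.39 log units; beyond the scatter). Compound 4 `CCOc1ccc2nc(NC(=O)CCCCC(=O)NO)sc2c1` keeps the chain of compound 3 and carries ethoxy in place of methyl on an aromatic carbon, ethoxy in place of methyl on an aromatic carbon. Ethoxy has not been measured on this core. Going by the values given here, the only measured change at an aromatic carbon is a 25-fold lower number from compound 1 to compound 2 (1.40 log units; beyond the scatter), a large step, but it involves methylsulfonyl and the longer chain, so it sets no direction here. The chain step does not apply, since the chain stays the same. The expected result is a 1.3-fold lower number from compound 3 to compound 4 (0.12 log units; within the scatter), with no shift beyond the scatter anticipated. For compound 4 the estimate is 10 ug/mL, with an expected range of 3.5 ug/mL to 30 ug/mL.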

Compound 4, half-maximal inhibitory concentration: 16.7 ug/mL
For compound 4 the middle estimate is 1.7-fold (0.22 log units) below the measured one; measured number inside the range.
By their numbers in this assay, from the lowest: compound 2; then compounds 3, 1 and 4 (each within the scatter of the next).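

In this assay, ethoxy in place of methyl on this aromatic carbon gives a step that stays within the scatter (a 1.3-fold higher number from compound 3 to compound 4 (0.10 log units; within the scatter)). On the shorter chain, this position therefore accepts a larger group carrying an oxygen without a measurable shift, whereas the step between methylsulfonyl and methyl on the longer chain was large (a 25-fold lower number from compound 1 to compound 2 (1.40 log units; beyond the scatter)). No measured evidence bears on this result.

On these data alone, whether ethoxy would behave the same way on the longer chain of compound 2 remains open. So does the effect of an amine or a carboxylic acid at this aromatic carbon.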